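Extending the urea terminus of a quinazoline series

A few compounds are considered here, and "the series" means these few. Any claim that something is new, unique, unknown or untested is made for them only; others in the source may bear on it.

Measured so far:
compound 1, `COC(CCNC(=O)Nc1cc2c(Nc3ccc(F)c(Cl)c3)ncnc2cc1O[C@H]1CCOC1)OC`: 22000 nM
compound 2, `O=C(Nc1cc2c(Nc3ccc(F)c(Cl)c3)ncnc2cc1O[C@H]1CCOC1)N1CCC(F)CC1`: 3040 nM

In a functional assay on A-431 cells (Homo sapiens) for antiproliferative activity, read by sulforhodamine B assay, with a stated time of 72 h (a lower number here means a stronger inhibitor, a higher number a weaker inhibitor), compound 1 gives 22000 nM, and compound 2 gives 3040 nM. Going by the values given here, the single change between them, a piperidine in place of a dimethoxypropyl chain on the urea, produced a 7.2-fold lower number from compound 1 to compound 2 (0.86 log units; beyond the scatter). Among the compounds with values here, compound 2 therefore holds the lower of the two numbers, with compound 1 as its only neighbour.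

Compound 3, `O=C(Nc1cc2c(Nc3ccc(F)c(Cl)c3)ncnc2cc1O[C@H]1CCOC1)N1CCC(N2CCCC2)CC1`, has not been measured. It differs from compound 2 by pyrrolidin-1-yl in place of fluoro on a saturated ring carbon. Within the data shown here, only the step from compound 1 to compound 2 bears on the urea terminus, and it shows that changes here can move the number beyond the scatter; no measured step tells how a substituent on the saturated ring itself acts. A step of modest size or none beyond the scatter is therefore expected, with a slight lean toward a lower number, so that a 1.5-fold lower number from compound 2 to compound 3 (0.18 log units; within the scatter) is estimated. Compound 3 is expected to give 2000 nM, within 500 nM to 8000 nM.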

Compound 3, half-maximal inhibitory concentration: 317 nM
Beside the measured number, compound 3's estimate is 6.3-fold (0.80 log units) above it; the whole stated range lies above it.
By their numbers in this assay, from the lowest: compound 3; then compound 2; then compound 1.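

In this assay, going by these compounds alone, the saturated ring at the urea terminus proves to be a place where the substituent itself matters: pyrrolidin-1-yl in place of fluoro gives a 9.6-fold lower number from compound 2 to compound 3 (0.98 log units; beyond the scatter) as the only measured change on that ring, and it lies beyond the scatter. With 4-(pyrrolidin-1-yl)piperidin-1-yl in place of (3,3-dimethoxypropyl)amino on the carbonyl carbon, the full change gives a 69-fold lower number from compound 1 to compound 3 (1.84 log units; beyond the scatter) and so reaches a large step, with both steps along this series lowering the number. Nothing available explains either step.

The compounds shown do not tell whether the pyrrolidine ring or its nitrogen carries the effect. A dimethylamino group, a morpholine or a cyclopentyl group on the same ring carbon would bear on that question, as would a longer chain between that ring carbon and the amine.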